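The compounds below may be only part of what the source reports. "The series", "measured", "known", "first", "only" and "open" are said of these compounds alone.

Working notes on the series. Compound 1 `CCOC(=O)C1=C(C)NC(C)=C(C(=O)OC)C1c1[nH]c(CC)nc1Cl` and compound 2 `CCCOC(=O)C1=C(C)NC(C)=C(C(=O)OCC)C1c1[nH]c(CC)nc1Cl` share one core and differ only at the ester group. In an assay on ileum for inhibition of Voltage-dependent L-type calcium channel subunit alpha-1C (Cavia porcellus) (a lower number here means a stronger inhibitor, a higher number a weaker inhibitor), compound 1 gives 2.02 nM, and compound 2 gives 0.543 nM. Among the measured compounds shown here, the single step measured so far, a 3.7-fold lower number from compound 1 to compound 2 (0.57 log units; beyond the scatter), comes from ethyl in place of hydrogen on a saturated chain carbon bound to an oxygen next to a carbonyl group. For the measured compounds named here, on the two numbers in hand, compound 2 stands with the lowest value; its only neighbour, compound 1, lies a higher number away, beyond the scatter.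

Compound 3 `CCOC(=O)C1=C(C)NC(C)=C(C(=O)OCC2CCCCC2)C1c1[nH]c(CC)nc1Cl` extends the same ester position: cyclohexyl in place of ethyl on a saturated chain carbon bound to an oxygen next to a carbonyl group. Going by the values given here, only the step from compound 1 to compound 2 bears on this change, and it shows that growing this chain helped modestly. Cyclohexyl is a larger addition than ethyl, but no second step is available to say whether the gain continues; a further small gain or no step beyond the scatter in this assay is the expectation. The step from compound 2 to compound 3 is estimated as a 1.4-fold lower number from compound 2 to compound 3 (0.13 log units; within the scatter). For compound 3 the expected value in this assay is 0.4 nM, with a range from 0.12 nM to 1.3 nM.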

Compound 3, half-maximal inhibitory concentration: 1.07 nM
Beside the measured number, compound 3's estimate is 2.7-fold (0.43 log units) below it, within the range that was stated.
By their numbers in this assay, from the lowest: compounds 2, 3 and 1 (each within the scatter of the next, the first and the last beyond it).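

In this assay, among the compounds shown here, cyclohexyl on this saturated chain carbon gives no step that can be read against either smaller ester: a 2.0-fold higher number from compound 2 to compound 3 (0.29 log units; within the scatter) and a 1.9-fold lower number from compound 1 to compound 3 (0.28 log units; within the scatter) both lie within the scatter, so compound 3 cannot be separated from compound 1 or compound 2. The gain seen with ethyl in place of hydrogen therefore does not continue as a trend with cyclohexyl, although compound 1 and compound 2 themselves remain apart beyond the scatter. Nothing in hand bears on the reason for this result.

Going by these compounds, whether the ring itself or only the carbon count sets this level remains open. An open butyl or hexyl chain on the same carbon, or an amine or a carboxylic acid at the end of the chain, would test how far this position tolerates change.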